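Shifting the fluorine: from compound 1 to compound 4

This account rests on a few compounds, and the source may have more. Where it says the series, first, only, none or still open, it means among the compounds named here.

Compound 1, `CC1=C(/C=C/C(=O)/C=C/c2ccc(F)cc2)C(C)(C)CCC1`: 6200 nM
Compound 2, `CC1=C(/C=C/C(=O)/C=C/c2ccc(C#N)cc2)C(C)(C)CCC1`: 13200 nM
Compound 3, `CC1=C(/C=C/C(=O)/C=C/c2ccc([N+](=O)[O-])cc2)C(C)(C)CCC1`: 5500 nM

In a functional assay on MCF7 cells (Homo sapiens) for cytotoxicity, read by sulforhodamine B assay, with a stated time of 48 h (on this read-out higher numbers stand for weaker inhibition and lower numbers for stronger inhibition), compound 1 holds the second highest of the three numbers. Its nearest neighbour is compound 3, with a 1.1-fold lower number from compound 1 to compound 3 (0.05 log units; within the scatter); furthest is compound 2, with a 2.1-fold higher number from compound 1 to compound 2 (0.33 log units; beyond the scatter).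

Compound 4, `CC1=C(/C=C/C(=O)/C=C/c2ccccc2F)C(C)(C)CCC1`, differs from compound 1 by 2-fluorophenyl in place of 4-fluorophenyl on a double-bonded chain carbon bound to a double-bonded chain carbon. Among the measured compounds shown here, every measured step exchanges one group for another at the same place; none moves a group around the ring, so no measured step bears directly on this change. With nothing pointing either way, compound 4 is expected to sit close to compound 1, a step of no change at the digits printed from compound 1 to compound 4 (within the scatter) within the scatter. The estimate for compound 4 is 6200 nM, with a range from 2500 nM to 15000 nM.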

Compound 4, half-maximal inhibitory concentration: 11000 nM
Estimate against measurement, compound 4: 1.8-fold (0.25 log units) below; the measured number falls inside the stated range.
By their numbers in this assay, from the lowest: compounds 3, 1, 4 and 2 (each within the scatter of the next, the first and the last beyond it).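

In this assay, 2-fluorophenyl in place of 4-fluorophenyl gives a 1.8-fold higher number from compound 1 to compound 4 (0.25 log units; within the scatter). This is the first step shown in which the fluorine stays and only its place on the ring differs, and between these two placements the read-out shows no difference beyond the scatter. Nothing available explains this result or links it to any property of either group. The compounds shown leave open whether an amine or a carboxylic acid on this ring would stay in the same range. They also leave open whether a nitro group would behave as the fluorine does when its place on the ring differs.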